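Swapping the Benzyl Ether Group on Compound 1

This account rests on a few compounds, and the source may have more. Where it says the series, first, only, none or still open, it means among the compounds named here.

Compound 1 `COc1ccc(CO/N=C/c2c(-c3ccc4ccccc4c3)nc3occn23)cc1`: 4400 nM
Compound 2 `N#Cc1ccc(-c2nc3sccn3c2/C=N/OCc2ccc(Cl)c(Cl)c2)cc1`: 3400 nM
Compound 3 `Fc1ccc(-c2nc3sccn3c2/C=N/OCc2ccc(Cl)c(Cl)c2)cc1`: 670 nM

In an assay on HepG2 cells for agonist activity at nuclear receptor subfamily 1 group I member 3 (Homo sapiens), read by a luciferase reporter, with a stated time of 23 h (a higher number here means that more compound is needed for the effect, a lower number that less compound is needed), compound 1 gives 4400 nM, the highest of the three numbers; compound 2 sits within the scatter of it, while compound 3 lies well below both. Among the compounds with values here, the only one-place step among the measured compounds is a 5.1-fold lower number from compound 2 to compound 3 (0.71 log units; beyond the scatter), a modest shift that occurs on a different core and at a different position. Compound 4 `Clc1ccccc1CO/N=C/c1c(-c2ccc3ccccc3c2)nc2occn12` arises from compound 1 by 2-chlorophenyl in place of 4-methoxyphenyl on a saturated chain carbon bound to an oxygen on an unsaturated carbon. No measured step touches this benzyl ether position, so nothing anchors a direction; the single shown step only warns that one ring substituent can move the number modestly. For compound 4 no change beyond the scatter is expected, and the estimate is 3800 nM, between 1200 nM and 12000 nM, meaning an expected 1.2-fold lower number from compound 1 to compound 4 (0.06 log units; within the scatter).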

Compound 4, half-maximal effective concentration: 1100 nM
The estimate for compound 4 lay 3.5-fold (0.54 log units) above the measured number; the whole stated range lies above it.
By their numbers in this assay, from the lowest: compounds 3 and 4 (each within the scatter of the next); then compounds 2 and 1 (each within the scatter of the next).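

The benzyl ether position is not indifferent to what it carries in this assay: 2-chlorophenyl in place of 4-methoxyphenyl gives a 4.0-fold lower number from compound 1 to compound 4 (0.60 log units; beyond the scatter). Within the data shown here, the earlier compounds could not show this, as their only step lay at a different position on a different core. Nothing measured here accounts for the shift.

This one change replaces the methoxy group with chlorine and also moves the substituent to a different ring position, so the compounds shown cannot separate the two. Going by these compounds, how a plain phenyl, or a ring bearing an amine or a carboxylic acid, would compare remains open.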